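From Nitrile to Tetrazole: A Solubility Step

A few compounds are considered here, and "the series" means these few. Any claim that something is new, unique, unknown or untested is made for them only; others in the source may bear on it.

Measured compounds:
Compound 1, `O=C(c1ccc(F)c(O)c1)c1ccc2cc(O)ccc2n1`: > 200000 nM
Compound 2, `N#Cc1ccc2ccc(C(=O)c3ccc(F)c(O)c3)nc2c1`: 25000 nM

Both compounds were tested in a physicochemical assay for solubility, in phosphate buffer, with a stated time of 24 h, at pH 7.4, tested at 200 uM; a higher number here means a more soluble compound, a lower number a less soluble compound. Compound 1 gives > 200000 nM in this assay, and that value is a limit of the measurement rather than a number (the limit of > 200000 nM in this assay, at which 1 of the 2 values shown sits). Within the data shown here, compound 2 gives 25000 nM in this assay, which makes compound 2 the only compound with a plain number in the set. The other value, that of compound 1, is a limit. Among the measured compounds shown here, the two measured compounds differ in more than one place, so no single step between them can be read, and their values show only that compound 2 sits at a number while compound 1 sits at the limit.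

Compound 3, `O=C(c1ccc(F)c(O)c1)c1ccc2ccc(-c3nnn[nH]3)cc2n1`, has not yet been measured. It differs from compound 2 in one place: 1H-tetrazol-5-yl in place of cyano on an aromatic carbon. Solubility is expected to rise from compound 2 to compound 3 by a 6.0-fold higher number from compound 2 to compound 3 (0.78 log units; beyond the scatter), a step beyond the usual scatter. Compound 3 is estimated at 150000 nM in this assay, within a range from 40000 nM to 200000 nM. The upper end of that range touches the limit, so the assay may report only a limit for compound 3.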

Compound 3, solubility: 50000 nM
For compound 3 the middle estimate is 3.0-fold (0.48 log units) above the measured one, and the stated range covers the measured number.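

Among these compounds, putting 1H-tetrazol-5-yl in place of cyano on this aromatic carbon gives the first step that can be read in this assay: a 2.0-fold higher number from compound 2 to compound 3 (0.30 log units; within the scatter). At this position, then, a change that brings in a five-membered aromatic ring with 4 hetero atoms and a hydrogen-bond donor gives two readings that cannot be told apart, so this pair shows no real difference in either direction. Among the compounds shown here, the one value in the set that is a limit and not a number remains that of compound 1, so any later step from compound 3 at this position could still be read as a number in either direction: the limit of > 200000 nM in this assay, at which 1 of the 3 values shown sits.

The compounds shown leave open whether another group on this same aromatic carbon, such as a carboxylic acid or an amine, would give a step beyond the scatter. A single pair within the scatter also says nothing about what either group contributes on its own, and whether the same swap would read the same way on a different core remains an open question.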